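A Second Methoxy Group and Tolerance in MT2 Cells

The compounds below may be only part of what the source reports. "The series", "measured", "known", "first", "only" and "open" are said of these compounds alone.

Measured compounds:
compound 1, `CC(C)=CCOc1cc(Nc2ncnc(Cl)n2)ccc1Cl`: 45000 nM
compound 2, `COc1nc(Cl)nc(Nc2ccc(Cl)c(OCC=C(C)C)c2)n1`: 26000 nM
compound 3, `COc1ncnc(Nc2ccc(C#N)c(OCC=C(C)C)c2)n1`: 42000 nM

Three compounds were measured in an ADME assay on MT2 cells (Homo sapiens) for cytotoxicity; a lower number here means that less compound is tolerated, a higher number that more compound is tolerated. In this assay compound 1 gives 45000 nM, compound 2 gives 26000 nM and compound 3 gives 42000 nM. Compound 2 differs from compound 1 by methoxy in place of hydrogen on an aromatic carbon, and that step, a 1.7-fold lower number from compound 1 to compound 2 (0.24 log units; within the scatter), lies within the scatter. The difference between the core of compound 1 and the core of compound 3 is not broken down here; their two values stand close together.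

Compound 4, `COc1nc(Nc2ccc(C#N)c(OCC=C(C)C)c2)nc(OC)n1`, has not been measured. It differs from compound 3 by methoxy in place of hydrogen on an aromatic carbon. For the measured compounds named here, this is the same kind of change as the one from compound 1 to compound 2, but the surroundings differ: in compound 1 the place is meta to a chloro group, in compound 3 it is meta to a methoxy group.

Since the earlier change gave only a 1.7-fold lower number from compound 1 to compound 2 (0.24 log units; within the scatter), the step from compound 3 to compound 4 in this assay is expected to be of similar size, about a 1.4-fold lower number from compound 3 to compound 4 (0.15 log units; within the scatter). Compound 4 is therefore estimated at 30000 nM in this assay. For compound 4 the range expected is 15000 nM to 60000 nM.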

Compound 4, half-maximal cytotoxic concentration: > 100000 nM
Compound 4 was reported as a limit; the forecaster's own chance of this, stated with the estimate: 20%; at least 3.3-fold (0.52 log units) between middle value and limit.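

In this assay compound 4 is reported only as a limit and not as a number: the limit of > 100000 nM in this assay, at which 1 of the 4 values shown sits. Methoxy in place of hydrogen on an aromatic carbon here gives an at least 2.3-fold higher number from compound 3 to compound 4 (0.37 log units; beyond the scatter), so the change as seen on the core of compound 1 does not carry over to the core of compound 3, and the two steps differ: the same change on two cores in this assay, a 1.7-fold lower number (0.24 log units; within the scatter) from compound 1 to compound 2 and an at least 2.3-fold higher number (0.37 log units; beyond the scatter) from compound 3 to compound 4, at least 4.1-fold (0.61 log units) apart, beyond the scatter of two such steps. This does not show which difference between the two cores goes with the gap, how large the step from compound 3 to compound 4 really is, or how the same change would read on any third core, since two pairs make no rule for the series.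

The compounds shown leave open whether an ethoxy group, an amine or a longer alkoxy chain in the same place would read like the methoxy group on the core of compound 3. They also leave open which of the differences between the two cores matters, the nitrile or the chloro groups, as no pair shown changes one of these alone while the methoxy step is repeated.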